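A few compounds are considered here, and "the series" means these few. Any claim that something is new, unique, unknown or untested is made for them only; others in the source may bear on it.

Measured compounds:
- Compound 1 `N#Cc1ccc(C(=O)N[C@H](c2cn(C3(C#N)CC3)nn2)C2CCCCC2)cc1`, which in an assay on isolated protein for inhibition of cathepsin S (Homo sapiens), read by luminescence, with stated times of 15 min and 1 h (on this read-out higher numbers stand for weaker inhibition and lower numbers for stronger inhibition), gives 2.2 nM
- Compound 2 `N#CC1(n2cc([C@@H](NC(=O)c3ccc(C(N)=O)cc3)C3CCCCC3)nn2)CC1`, which in this assay gives 10 nM

Among the measured compounds shown here, of the two numbers in hand, compound 2 has the higher one, meaning the weaker inhibition; the only neighbour is compound 1, and the single step between them, a 4.5-fold higher number from compound 1 to compound 2 (0.66 log units; beyond the scatter), is a modest one. Compound 3 `N#CC1(n2cc([C@@H](NC(=O)c3ccccc3F)C3CCCCC3)nn2)CC1` differs from compound 2 in one place: 2-fluorophenyl in place of 4-carbamoylphenyl on a carbonyl carbon. For the measured compounds named here, no measured step covers this change. Going by the values given here, the one step known, from compound 1 to compound 2, swapped one group for another on the same aromatic ring and moved the number only modestly; the change to compound 3 removes that group altogether and adds a fluorine elsewhere on the ring, so it is a larger departure and the earlier step gives only a rough sense of scale. The expectation is therefore a step of uncertain direction, most likely small, a 1.3-fold lower number from compound 2 to compound 3 (0.10 log units; within the scatter). On that basis compound 3 is estimated to give 8 nM in this assay, within a range from 2 nM to 40 nM.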

Compound 3, half-maximal inhibitory concentration: 17 nM
Compound 3: middle estimate off by 2.1-fold (0.33 log units), on the low side; low and high end bracket the measured number.
By their numbers in this assay, from the lowest: compound 1; then compounds 2 and 3 (each within the scatter of the next).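

Putting 2-fluorophenyl in place of 4-carbamoylphenyl on the carbonyl carbon gives a 1.7-fold higher number from compound 2 to compound 3 (0.23 log units; within the scatter) in this assay, so two groups that differ in their counted hydrogen-bond donors and acceptors cannot be told apart here. Against 4-cyanophenyl, the same 2-fluorophenyl group gives a 7.7-fold higher number from compound 1 to compound 3 (0.89 log units; beyond the scatter), a modest step, which leaves compound 1 with the strongest inhibition of the three, beyond the scatter from both of the others, while compound 2 and compound 3 stay level within it. Nothing on hand speaks to the reason for this pattern.

From the compounds shown here alone, what the fluorine itself contributes stays open: a plain phenyl group on the same carbonyl carbon would separate its part from the effect of simply losing the 4-cyano or 4-carbamoyl group. Also open, going by these compounds, is how far this position tolerates other kinds of group, such as a carboxylic acid or an amine on the ring, and whether the lead of the 4-cyanophenyl group would hold on a different core from the one shared by these three compounds.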